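A Methoxy Group Added Where Cytotoxicity Readings Are Only Limits

The source may hold more compounds than are shown below. What is called first, only, known or untested is meant among the compounds shown, and "the series" means these compounds.

In an ADME assay on MT4 cells (Homo sapiens) for cytotoxicity, read by MTT assay (on this read-out lower numbers stand for higher toxicity in this test and higher numbers for lower toxicity in this test), compound 3 `O=C(CSc1nc(Cc2c(Cl)cccc2Cl)cc(=O)[nH]1)c1ccccc1` gives > 12000 nM, which is a limit of the assay and not a number. Compound 1 `O=C(CSc1nc(Cc2c(F)cccc2F)cc(=O)[nH]1)c1ccccc1` gives > 67000 nM, also a limit. Compound 2 `Cc1ccc(CSc2nc(Cc3c(F)cccc3F)c(C)c(=O)[nH]2)c(C)c1` gives > 65000 nM, again a limit. So no compound here has an exact reading, and compound 3 cannot be ranked against the other two.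

Compound 4 `COc1ccc(C(=O)CSc2nc(Cc3c(Cl)cccc3Cl)cc(=O)[nH]2)cc1` turns the phenyl of compound 3 into 4-methoxyphenyl, with methoxy in place of hydrogen on an aromatic carbon.

The only measured step among these compounds is a step that the two limits leave unreadable from compound 1 to compound 3. It exchanges 2,6-difluorophenyl for 2,6-dichlorophenyl, so it concerns a different part of the molecule, and its size cannot be read. No measured step shows what a methoxy does here, so the data give no reason to expect a shift in either direction.

The step expected in this assay is a step that the limit leaves unreadable from compound 3 to compound 4, and no change beyond the usual scatter is anticipated. With compound 3 at > 12000 nM as the nearest reference, compound 4 is expected near 15000 nM, with an estimated range from 6000 nM to 60000 nM. It may well be reported only as a limit.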

Compound 4, half-maximal cytotoxic concentration: > 11000 nM
Compound 4 ended at the assay's limit; the forecaster's own chance of this, stated with the estimate: 75%; the middle value lies beyond the limit too.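

In this assay compound 4 gives > 11000 nM as a limit of the assay and not a number. Compound 3 gives > 12000 nM as a limit too, so the step between these two compounds cannot be read. The compounds shown leave open whether methoxy in place of hydrogen on an aromatic carbon changes the cytotoxicity reading at all.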